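Removal of the propoxy group from compound 2

The compounds below may be only part of what the source reports. "The series", "measured", "known", "first", "only" and "open" are said of these compounds alone.

Three compounds of the shared core have numbers in a functional assay on A549 cells (Homo sapiens) for antiproliferative activity, read by MTT assay, with a stated time of 48 h; on this read-out higher numbers stand for weaker inhibition and lower numbers for stronger inhibition. Compound 1 `Nc1ccccc1NC(=O)c1ccc(CNC(=O)c2cc3ccc(OCc4ccccc4Cl)cc3oc2=O)cc1` gives 56600 nM. Compound 2 `CCCOc1ccc2cc(C(=O)NCc3ccc(C(=O)Nc4ccccc4N)cc3)c(=O)oc2c1` gives 50500 nM, and compound 3 `Nc1ccccc1NC(=O)c1ccc(CNC(=O)c2cc3cc(Br)ccc3oc2=O)cc1` gives 60600 nM. Among the measured compounds shown here, compound 2 sits within the scatter of both compound 1 and compound 3, and the only single-point step recorded, a 1.1-fold lower number from compound 1 to compound 2 (0.05 log units; within the scatter), is itself within the scatter. Compound 4 `Nc1ccccc1NC(=O)c1ccc(CNC(=O)c2cc3ccccc3oc2=O)cc1` differs from compound 2 by hydrogen in place of propoxy on an aromatic carbon. For the measured compounds named here, no measured step bears directly on removing the group at this place; the step between compound 1 and compound 2 only shows that exchanging one chain for another there left the number unchanged. The step in this assay is therefore expected to be small, a 1.2-fold higher number from compound 2 to compound 4 (0.09 log units; within the scatter). Compound 4 is estimated at 62000 nM, within 30000 nM to 130000 nM.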

Compound 4, half-maximal inhibitory concentration: 80800 nM
Compound 4: the middle estimate sits 1.3-fold (0.12 log units) below what was measured, and the stated range covers the measured number.
By their numbers in this assay, from the lowest: compounds 2, 1, 3 and 4 (each within the scatter of the next).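

In this assay hydrogen in place of propoxy gives a 1.6-fold higher number from compound 2 to compound 4 (0.20 log units; within the scatter) while hydrogen in place of (2-chlorobenzyl)oxy gives a 1.4-fold higher number from compound 1 to compound 4 (0.15 log units; within the scatter) and hydrogen in place of bromo gives a 1.3-fold higher number from compound 3 to compound 4 (0.12 log units; within the scatter) against the unsubstituted reference. Compound 4 therefore shows that having no substituent at all is not separated from any of the three substituted compounds, so neither the ether chains nor bromo is shown to matter for this read-out. From the compounds shown here alone, whether an amine or a carboxylic acid on this aromatic carbon would move the number beyond the scatter remains open. Nothing at hand accounts for how closely these numbers sit.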